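Heteroaryl methyl variations on the piperazine arm

This account rests on a few compounds, and the source may have more. Where it says the series, first, only, none or still open, it means among the compounds named here.

Measured compounds:
compound 1, `Cc1ccc(CN2CCN(c3cccc4[nH]c(-c5ccc(C(C)(C)C)cc5)nc34)CC2)o1` — 705 nM
compound 2, `Cn1cnc(CN2CCN(c3cccc4[nH]c(-c5ccc(C(C)(C)C)cc5)nc34)CC2)c1` — 33 nM
compound 3, `Cc1nc(C)c(CN2CCN(c3cccc4[nH]c(-c5ccc(C(C)(C)C)cc5)nc34)CC2)o1` — 31 nM

In an assay on isolated protein for displacement of a labelled ligand from Gonadotropin-releasing hormone receptor (Homo sapiens) (a higher number here means a weaker inhibitor, a lower number a stronger inhibitor), compound 3 gives the lowest number of the three, but compound 2 sits within the scatter of it, so the two cannot be ordered. Compound 1 is clearly weaker than both: a 23-fold lower number from compound 1 to compound 3 (1.36 log units; beyond the scatter) and a 21-fold lower number from compound 1 to compound 2 (1.33 log units; beyond the scatter). Compound 4 `CCc1nc(C)c(CN2CCN(c3cccc4[nH]c(-c5ccc(C(C)(C)C)cc5)nc34)CC2)o1` differs from compound 3 by methyl in place of hydrogen on a saturated chain carbon bound to an aromatic carbon. No measured step bears on this position; the three steps shown all exchange the whole heteroaryl ring, and the two ring-for-ring changes away from compound 1 were large. For this small addition no step beyond the scatter is expected: a 1.1-fold lower number from compound 3 to compound 4 (0.04 log units; within the scatter). Compound 4 is therefore estimated at 28 nM, with a range of 12 nM to 70 nM.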

Compound 4, half-maximal inhibitory concentration: 37 nM
Estimate against measurement, compound 4: 1.3-fold (0.12 log units) below; low and high end bracket the measured number.
By their numbers in this assay, from the lowest: compounds 3, 2 and 4 (each within the scatter of the next); then compound 1.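

In this assay, going from methyl to ethyl on the oxazole ring gives a 1.2-fold higher number from compound 3 to compound 4 (0.08 log units; within the scatter), so this position takes the extra carbon without a readable change. The 2-ethyl-4-methyl-1,3-oxazol-5-yl group also stays level with 1-methyl-1H-imidazol-4-yl, a 1.1-fold higher number from compound 2 to compound 4 (0.05 log units; within the scatter), and keeps the large gain over 5-methylfuran-2-yl, a 19-fold lower number from compound 1 to compound 4 (1.28 log units; beyond the scatter). No evidence on the reason for this tolerance is available.

From the compounds shown here alone, whether a propyl chain, a cyclopropyl ring or an amine in place of the ethyl would stay within the scatter of compound 4 remains open.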